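The source may hold more compounds than are shown below. What is called first, only, known or untested is meant among the compounds shown, and "the series" means these compounds.

Measured in a functional assay on HCT-15 cells (Homo sapiens) for antiproliferative activity, read by sulforhodamine B assay, with a stated time of 48 h, tested at 50 uM; on this read-out higher numbers stand for more inhibition at the one concentration tested (going by the name of the read-out) and lower numbers for less inhibition:
- compound 1 `CC1=CC[C@H](C(C)C)c2cc(C)c(OC(=O)c3ccc(C)cc3)cc21`: 78.9%
- compound 2 `CC1=CC[C@H](C(C)C)c2cc(C)c(OC(=O)c3ccc([N+](=O)[O-])cc3)cc21`: 67.8%
- compound 3 `CC1=CC[C@H](C(C)C)c2cc(C)c(OC(=O)c3cccc(Cl)c3)cc21`: 5.3%

Compound 3 stands lowest of the three numbers, far below the other two: a number 73.6 percentage points lower from compound 1 to compound 3 (beyond the scatter), and a number 62.5 percentage points lower from compound 2 to compound 3 (beyond the scatter). Both of those steps are beyond the scatter and large, and both involve the same exchange of the aryl group on the carbonyl carbon, with a 3-chlorophenyl member at the low end each time. For the measured compounds named here, the one step that stays among 4-substituted phenyl groups is much smaller: a number 11.1 percentage points lower from compound 1 to compound 2 (beyond the scatter), modest though beyond the scatter.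

Compound 4 `COc1ccc(C(=O)Oc2cc3c(cc2C)[C@@H](C(C)C)CC=C3C)cc1` differs from compound 3 in one place: 4-methoxyphenyl in place of 3-chlorophenyl on a carbonyl carbon. The two large steps bear directly on this change, read in reverse: removing 3-chlorophenyl in favour of a phenyl carrying a single substituent in the 4-place has, on the evidence of compounds 1 and 2, gone with numbers in the upper part of the range. The modest size of the step from 4-methylphenyl to 4-nitrophenyl suggests that the identity of that substituent matters less than its presence. Going by the values given here, a large upward step is therefore expected in this assay, a number 59.7 percentage points higher from compound 3 to compound 4 (beyond the scatter), with only one 3-chlorophenyl member to anchor the low end. Compound 4 is estimated at 65%, between 30% and 85%.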

Compound 4, a percentage reported as inhibition, at one concentration (the size of the read-out at that concentration, not a potency): 30.8%
Estimate against measurement, compound 4: 34.2 percentage points above; the range from low to high includes it.
By their numbers in this assay, from the lowest: compound 3; then compound 4; then compound 2; then compound 1.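

In this assay the 4-methoxyphenyl group recovers only part of what the 3-chlorophenyl group loses: the step up (a number 25.5 percentage points higher from compound 3 to compound 4 (beyond the scatter)) is modest, whereas the steps down from the other two (a number 37 percentage points lower from compound 2 to compound 4 (beyond the scatter)) and (a number 48.1 percentage points lower from compound 1 to compound 4 (beyond the scatter)) are both large. The substituent on the phenyl group attached to the carbonyl carbon therefore matters more than compounds 1 and 2 alone suggested, and the presence of a group at that ring position does not by itself secure a number in the upper part of the range. Nothing shown here accounts for the place of the methoxy member among these esters.

Still open, going by these compounds, is whether the low number of compound 3 belongs to chlorine or to where it sits on the ring, a question that 4-chlorophenyl and 3-methylphenyl esters would separate. Also open, on these data alone, is how an unsubstituted phenyl group, or a 4-aminophenyl or 4-carboxyphenyl group, would compare on the same core, and how these single-concentration readings relate to potency.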